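The source may report more compounds than this note shows. Statements on the series, on what has been measured and on what is new or still open speak of the compounds shown alone.

Measured so far in an assay on HEK293 cells for positive allosteric modulation of metabotropic glutamate receptor 5 (Homo sapiens), read by FLIPR, with a stated time of 1 h; a higher number here means that more compound is needed for the effect, a lower number that less compound is needed:
compound 1, `CN1CCc2nc(C#Cc3ccccc3)sc2C1`: 34 nM
compound 2, `Cc1cccc(C(=O)N2CCc3nc(C#Cc4ccccc4)sc3C2)n1`: 160 nM

Within the data shown here, compound 2 has the highest number of the two; compound 1 is its only neighbour, with a lower value beyond the scatter. Compound 3, `O=C(N1CCCCC1)N1CCc2nc(C#Cc3ccccc3)sc2C1`, remains to be measured in this assay. It differs from compound 2 by piperidin-1-yl in place of 6-methylpyridin-2-yl on a carbonyl carbon. Among the measured compounds shown here, no pair among the measured compounds shows this change, so no step size is given by the data. The step from compound 2 to compound 3 is expected to be a 1.6-fold higher number from compound 2 to compound 3 (0.19 log units; within the scatter), a modest rise. Compound 3 is therefore estimated at 250 nM, within the range 80 nM to 800 nM.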

Compound 3, half-maximal effective concentration: 75 nM
Compound 3: the middle estimate sits 3.3-fold (0.52 log units) above what was measured, outside the stated range (below it).
By their numbers in this assay, from the lowest: compound 1; then compound 3; then compound 2.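

In this assay there is a 2.1-fold lower number from compound 2 to compound 3 (0.33 log units; beyond the scatter) with piperidin-1-yl in place of 6-methylpyridin-2-yl on a carbonyl carbon, so an aromatic ring on this carbonyl is not required for the effect. Putting (piperidin-1-yl)carbonyl in place of methyl on an amine nitrogen in a ring still gives a 2.2-fold higher number from compound 1 to compound 3 (0.34 log units; beyond the scatter) and does not recover the level of the methyl compound. No measurement at hand accounts for either step.

On these data alone, whether a morpholine ring or an open-chain diethylamino group on the carbonyl would follow piperidin-1-yl remains open. So does the effect of a simple acetyl group on the ring nitrogen.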